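Moving a hydroxyl around a pyridine-linked phenyl ring

The compounds below may be only part of what the source reports. "The series", "measured", "known", "first", "only" and "open" are said of these compounds alone.

Measured compounds:
compound 1 `Oc1ccc(-c2cc(-c3ccco3)cc(-c3ccc(O)cc3)n2)cc1`, > 50000 nM
compound 2 `Oc1ccc(-c2cc(-c3ccoc3)cc(-c3ccccc3O)n2)cc1`, > 50000 nM
compound 3 `Oc1ccc(-c2cc(-c3ccoc3)cc(-c3cccc(O)c3)n2)cc1`, 3310 nM

Among the measured compounds shown here, in a functional assay on HeLa cells (Homo sapiens) for cytotoxicity, read by CCK-8 assay (a higher number here means a weaker inhibitor, a lower number a stronger inhibitor), compound 3 is the only member of the set that gives an actual number; the other two values are limits. For compound 1 the value of > 50000 nM is a limit of the assay, not a number. For compound 2 the value of > 50000 nM is likewise a limit. For the measured compounds named here, the one measured step, an at least 15-fold lower number from compound 2 to compound 3 (1.17 log units; beyond the scatter), shows that the position of the hydroxyl on this phenyl ring matters a great deal, since the limit of > 50000 nM in this assay, at which 2 of the 3 values shown sit, is left behind only by compound 3.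

Compound 4 `Oc1ccc(-c2cc(-c3ccoc3)cc(-c3ccc(O)cc3)n2)cc1` continues the same move: 4-hydroxyphenyl in place of 3-hydroxyphenyl on an aromatic carbon. Going by the values given here, no measured step covers this exact change, and compound 1, which also carries two 4-hydroxyphenyl groups, sits at the limit. Compound 4 is therefore expected to lose potency, with an estimated step of a 6.0-fold higher number from compound 3 to compound 4 (0.78 log units; beyond the scatter), giving an expected value of 20000 nM in a range from 4000 nM to 60000 nM.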

Compound 4, half-maximal inhibitory concentration: 3420 nM
The estimate for compound 4 lay 5.8-fold (0.77 log units) above the measured number, outside the stated range (below it).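

Among the compounds shown here, on the ring position next to the ring nitrogen, the earlier compounds left open whether the 3-hydroxyphenyl group was special, but in this assay the 4-hydroxyphenyl group does not set itself apart from it, with a 1.0-fold higher number from compound 3 to compound 4 (0.01 log units; within the scatter). So far only the 2-hydroxyphenyl group stands apart, with an at least 14-fold lower number from compound 2 to compound 4 (1.16 log units; beyond the scatter), and the furan attachment turns out to matter as well, with an at least 14-fold lower number from compound 1 to compound 4 (1.16 log units; beyond the scatter). Both of these large steps start from a limit and not from a number, so their true size stays unknown: the limit of > 50000 nM in this assay, at which 2 of the 4 values shown sit.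

The compounds shown leave open whether the hydroxyl itself is needed, since an amine or a methoxy group in its place would test that. They also leave open how a furan-2-yl group behaves alongside a 3-hydroxyphenyl group.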